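Swapping the Para Substituent on the Benzoate Ester

The source may hold more compounds than are shown below. What is called first, only, known or untested is meant among the compounds shown, and "the series" means these compounds.

Measured compounds:
- compound 1, `CC1=CC[C@H](C(C)C)c2cc(C)c(OC(=O)c3ccccc3)cc21`: 49.5%
- compound 2, `CC1=CC[C@H](C(C)C)c2cc(C)c(OC(=O)c3ccc(C(F)(F)F)cc3)cc21`: 6.4%
- compound 3, `CC1=CC[C@H](C(C)C)c2cc(C)c(OC(=O)c3ccc(Cl)cc3)cc21`: 47.4%

All three share one core, an ester of a benzoic acid, and differ only in the group on the outer benzene ring. In a functional assay on HCT-15 cells (Homo sapiens) for antiproliferative activity, read by sulforhodamine B assay, with a stated time of 48 h, tested at 50 uM (on this read-out higher numbers stand for more inhibition at the one concentration tested (going by the name of the read-out) and lower numbers for less inhibition), compound 3 gives 47.4%, which places it second of the three, with compound 1 so close that the two cannot be told apart: the step of a number 2.1 percentage points lower from compound 1 to compound 3 (within the scatter). Within the data shown here, the only large change seen so far is a number 43.1 percentage points lower from compound 1 to compound 2 (beyond the scatter), and the mirror of it, a number 41 percentage points higher from compound 2 to compound 3 (beyond the scatter).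

Compound 4, `COc1ccc(C(=O)Oc2cc3c(cc2C)[C@@H](C(C)C)CC=C3C)cc1`, has not yet been measured. It differs from compound 3 in one place: methoxy in place of chloro on an aromatic carbon. Among the measured compounds shown here, no measured step involves a methoxy group, so the bearing steps are indirect. Replacing hydrogen by chloro changed almost nothing, while replacing hydrogen by trifluoromethyl cut the inhibition sharply; methoxy is neither of these, so the expectation is uncertain. The expected step is a number 7.4 percentage points lower from compound 3 to compound 4 (within the scatter), that is, a modest fall, possibly within the scatter but with a wide range. Compound 4 is therefore estimated at 40%, between 8% and 60%.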

Compound 4, a percentage reported as inhibition, at one concentration (the size of the read-out at that concentration, not a potency): 30.8%
Estimate against measurement, compound 4: 9.2 percentage points above; low and high end bracket the measured number.
By their numbers in this assay, from the lowest: compound 2; then compound 4; then compounds 3 and 1 (each within the scatter of the next).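

In this assay, among these compounds, methoxy is the first group at this position to lower the number only part of the way: the fall is clear against hydrogen (a number 18.7 percentage points lower from compound 1 to compound 4 (beyond the scatter)) and against chloro (a number 16.6 percentage points lower from compound 3 to compound 4 (beyond the scatter)), yet the methoxy compound still stands well clear of the trifluoromethyl compound (a number 24.4 percentage points higher from compound 2 to compound 4 (beyond the scatter)). The position therefore no longer divides into groups that change nothing and a group that nearly removes the inhibition, since the four compounds now fall on three separate levels, with compounds 1 and 3 sharing the top one. The swap from chloro to methoxy also adds a hydrogen-bond acceptor and one heavy atom, but nothing measured here links either difference to the drop in inhibition.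

The compounds shown leave open how an amine or a carboxylic acid would read at this position, and whether a longer chain such as ethoxy in place of methoxy would move the number toward compound 2 or back toward compound 3. They also leave open whether these three levels would hold as true potencies, since each number comes from a single concentration.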